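This account rests on a few compounds, and the source may have more. Where it says the series, first, only, none or still open, it means among the compounds named here.

Compound 1, with the structure `N#Cc1ccc(Nc2nccc(Nc3c(Cl)cc(Cl)cc3Cl)n2)cc1`, is the most polar of the three measured compounds in a physicochemical assay for lipophilicity (a lower number here means a more polar compound, a higher number a more lipophilic compound), where compound 1 gives 0.51. Compound 2, `Cc1cc(Cl)cc(Cl)c1Nc1ccnc(Nc2ccc(C#N)cc2)n1`, differs from it in a single place: methyl in place of chloro on an aromatic carbon. In this assay compound 2 gives 0.89, so the step of a number 0.38 log units higher from compound 1 to compound 2 (beyond the scatter) is a modest rise that lies beyond the usual scatter. Compound 3, `Cc1cc(C#N)cc(C)c1Nc1nc(Nc2ccc(C#N)cc2)ncc1Cl`, has a different core, and the difference between the two cores is not broken down here. In this assay compound 3 gives 1.11; next to compound 2 this lies within the scatter, while against compound 1 the gap is beyond it.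

Compound 4, `Cc1cnc(Nc2ccc(C#N)cc2)nc1Nc1c(C)cc(C#N)cc1C`, has not yet been measured. It differs from compound 3 in one place: methyl in place of chloro on an aromatic carbon. Within the data shown here, this is the same kind of change as the one from compound 1 to compound 2, but not the same: there the methyl entered on a six-membered aromatic ring of carbon only, meta to two chloro groups, whereas here it enters on a six-membered aromatic ring with 2 nitrogen, two atoms from the ring nitrogen and para to a (4-cyanophenyl)amino group. Among the measured compounds shown here, the one measured step of this kind, a number 0.38 log units higher from compound 1 to compound 2 (beyond the scatter), is the only guide. On that basis the step from compound 3 to compound 4 is expected to be a number 0.29 log units higher from compound 3 to compound 4 (within the scatter), a rise of comparable size but with wider uncertainty because the surroundings differ. Compound 4 is therefore estimated to give 1.4 in this assay, somewhere between 1 and 1.8.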

Compound 4, partition coefficient: 1.49
Beside the measured number, compound 4's estimate is 0.09 log units below it; the range from low to high includes it.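

In this assay, methyl in place of chloro on an aromatic carbon gives a number 0.38 log units higher from compound 3 to compound 4 (beyond the scatter), and the same kind of change on the core of compound 1 gives a number 0.38 log units higher from compound 1 to compound 2 (beyond the scatter), so the two printed steps agree in direction and in size even though the surroundings differ. Among these compounds, this is a match between only two pairs, one with the change on a six-membered aromatic ring of carbon only and the other on a six-membered aromatic ring with 2 nitrogen, so it shows that the step carried over in this one case but does not establish a rule for other cores or other places. Nothing available here accounts for the agreement between the two steps, which may or may not have a common origin.

The compounds shown compare only chloro and methyl, which leaves open how an amine, a methoxy group or a longer chain such as ethyl would read at the place two atoms from the ring nitrogen. They also leave open whether the same step would recur with a carboxylic acid elsewhere on the molecule, or on a core that differs from both of those seen here.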